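Sulfonyl-group swaps and cytotoxicity on a shared core

The compounds below may be only part of what the source reports. "The series", "measured", "known", "first", "only" and "open" are said of these compounds alone.

Measured compounds:
Compound 1 `O=S(=O)(Nc1ccc2oc(-c3ccccc3)nc2c1)c1ccc(Cl)c(Cl)c1`: 71000 nM
Compound 2 `Cc1ccccc1S(=O)(=O)Nc1ccc2oc(-c3ccccc3)nc2c1`: 57000 nM
Compound 3 `O=S(=O)(Nc1ccc2oc(-c3ccccc3)nc2c1)c1cccs1`: 97000 nM

Three compounds share one core and differ only in the group on the sulfonyl sulfur. In an ADME assay on HEK293 cells (Homo sapiens) for cytotoxicity, read by resazurin assay, with a stated time of 48 h (on this read-out higher numbers stand for lower toxicity in this test and lower numbers for higher toxicity in this test), compound 1 gives 71000 nM, compound 2 gives 57000 nM and compound 3 gives 97000 nM. Compound 3 has the highest of the three numbers, yet its steps to the others are small: a 1.4-fold higher number from compound 1 to compound 3 (0.14 log units; within the scatter) and a 1.7-fold higher number from compound 2 to compound 3 (0.23 log units; within the scatter), both within the scatter, as is a 1.2-fold lower number from compound 1 to compound 2 (0.10 log units; within the scatter). The three compounds therefore cannot be ordered on these data.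

Compound 4 `O=S(=O)(Nc1ccc2oc(-c3ccccc3)nc2c1)c1ccc(O)cc1` is not yet measured. It differs from compound 3 by 4-hydroxyphenyl in place of thiophen-2-yl on a sulfonyl sulfur. All three measured steps bear on this change, since each also swaps the group on the sulfonyl sulfur, and none of them moved the number beyond the scatter. Compound 4 is therefore expected to show no step beyond the scatter, a 1.2-fold lower number from compound 3 to compound 4 (0.08 log units; within the scatter). Compound 4 is estimated at 80000 nM, with a range from 40000 nM to 160000 nM.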

Compound 4, half-maximal cytotoxic concentration: > 100000 nM
Compound 4: only a limit was reported; the forecaster's own chance of this, stated with the estimate: 15%; at least 1.2-fold (0.09 log units) between middle value and limit.
By their numbers in this assay, from the lowest: compounds 2, 1 and 3 (each within the scatter of the next). At a limit, above all of these: compound 4.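

Compound 4, which carries 4-hydroxyphenyl on the sulfonyl sulfur, is reported in this assay only as a limit: the limit of > 100000 nM in this assay, at which 1 of the 4 values shown sits. Read as floors, an at least 1.0-fold higher number from compound 3 to compound 4 (0.01 log units; that floor lies within the scatter) and an at least 1.7-fold higher number from compound 2 to compound 4 (0.24 log units; that floor lies within the scatter) and an at least 1.4-fold higher number from compound 1 to compound 4 (0.14 log units; that floor lies within the scatter) are all within the scatter, so compound 4 cannot yet be ordered against the other three compounds. What is new at this position is that a group bringing in a hydrogen-bond donor gives a reading that reaches the limit of the assay, whereas the three earlier groups all gave numbers.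

From the compounds shown here alone, how far the true value of compound 4 lies from those of the others remains unknown. The compounds shown also leave open whether an amine or a carboxylic acid in place of the hydroxyl group would reach the same limit.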